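The source may hold more compounds than are shown below. What is called first, only, known or untested is meant among the compounds shown, and "the series" means these compounds.

Of the compounds compared here, compound 1 `CC1(C)Oc2ccc(C#N)cc2[C@@H](/N=C(\NC#N)Oc2ccccc2)[C@@H]1O` gives only a limit in a functional assay (aorta) with Rattus norvegicus as the target (on this read-out higher numbers stand for weaker inhibition and lower numbers for stronger inhibition), > 100000 nM. Compound 2 `CC1(C)Oc2ccc(C#N)cc2[C@@H](/N=C(\NC#N)Sc2ccccc2)[C@@H]1O` gives 4900 nM, and compound 3 `COC(=O)c1ccc(N/C(=N/[C@@H]2c3cc(C#N)ccc3OC(C)(C)[C@H]2O)NC#N)cc1` stands higher at 18400 nM, making it the weaker of the two with real numbers. Compound 4 `CSc1cccc(N/C(=N/[C@@H]2c3cc(C#N)ccc3OC(C)(C)[C@H]2O)NC#N)c1` has 3-(methylsulfanyl)phenyl in place of the 4-(methoxycarbonyl)phenyl of compound 3 on an amine nitrogen: 3-(methylsulfanyl)phenyl in place of 4-(methoxycarbonyl)phenyl on an amine nitrogen. For the measured compounds named here, the only measured step, an at least 20-fold lower number from compound 1 to compound 2 (1.30 log units; beyond the scatter), is large, but it swaps a different group, so it offers only a loose guide and no measured step changes this substituent. Little change is therefore expected in this assay, and the estimated step is a 1.5-fold lower number from compound 3 to compound 4 (0.19 log units; within the scatter). For compound 4 the expected value is 12000 nM, with an estimated range of 4000 nM to 40000 nM.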

Compound 4, half-maximal inhibitory concentration: 1400 nM
The estimate for compound 4 lay 8.6-fold (0.93 log units) above the measured number, and the stated range ends above it.
By their numbers in this assay, from the lowest: compound 4; then compound 2; then compound 3. At a limit, above all of these: compound 1.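

In this assay, the group on the amine nitrogen turns out to matter a great deal: 3-(methylsulfanyl)phenyl in place of 4-(methoxycarbonyl)phenyl gives a 13-fold lower number from compound 3 to compound 4 (1.12 log units; beyond the scatter). Replacing phenylsulfanyl with (3-(methylsulfanyl)phenyl)amino on the carbon with a double bond to nitrogen gives a smaller change, a 3.5-fold lower number from compound 2 to compound 4 (0.54 log units; beyond the scatter). Replacing phenoxy there gives an at least 71-fold lower number from compound 1 to compound 4 (1.85 log units; beyond the scatter), but this step starts from a limit: the limit of > 100000 nM in this assay, at which 1 of the 4 values shown sits.

As far as these compounds go, the step from compound 3 swaps the whole substituted ring, so it remains open whether gaining methylsulfanyl or losing methoxycarbonyl counts more. From the compounds shown here alone, how a plain phenyl or a benzyl on that nitrogen would compare also remains open.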